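Compound 3 to Compound 4: The Same Atoms Rejoined

The source may hold more compounds than are shown below. What is called first, only, known or untested is meant among the compounds shown, and "the series" means these compounds.

In an ADME assay on microsomes from liver (Mus musculus, strain CD-1) for metabolic stability, read by LC-MS, tested at 2 uM (a higher number here means that the compound lasts longer, a lower number that the compound disappears faster), compound 3 `CN1CC(NC(=O)c2ccncc2Nc2cc(-c3ccc4ccn(C)c4c3)c3nccnc3c2)CCC1=O` gives 0.75 h. Compound 2 `CN1CCC(NC(=O)c2ccncc2Nc2cc(-c3ccc4ccn(C)c4c3)c3nccnc3c2)CC1=O` gives 0.717 h, and the two stand level within the scatter. For compound 1 `Cn1ccc2ccc(-c3cc(Nc4cnccc4C(=O)NC4CCNC(=O)C4)cc4nccnc34)cc21` the reading is only a limit, > 1 h.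

Compound 4 `CC(=O)N1CC(CNC(=O)c2ccncc2Nc2cc(-c3ccc4ccn(C)c4c3)c3nccnc3c2)C1` carries (1-acetylazetidin-3-yl)methyl in place of 1-methyl-6-oxopiperidin-3-yl on an amide-type nitrogen. Going by the values given here, two measured steps bear on this site. One is a 1.0-fold higher number from compound 2 to compound 3 (0.02 log units; within the scatter), and the other is an at least 1.3-fold lower number from compound 1 to compound 3 (0.12 log units; that floor lies within the scatter). Both lie within the scatter, although the second is only a floor set by a limit. Among the compounds with values here, no measured step introduces the (1-acetylazetidin-3-yl)methyl group, so this guidance is indirect. With compound 3 at 0.75 h as the starting point, the expected change is a 1.1-fold lower number from compound 3 to compound 4 (0.03 log units; within the scatter), which means no step beyond the scatter is expected in this assay. For compound 4 the estimated half-life is 0.7 h, with an expected range of 0.35 h to 1.4 h.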

Compound 4, half-life: > 1 h
Compound 4 was reported as a limit (the forecaster's own chance of this, stated with the estimate: 20%); at least 1.4-fold (0.15 log units) between middle value and limit.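

In this assay, moving the same atoms from 1-methyl-6-oxopiperidin-3-yl into (1-acetylazetidin-3-yl)methyl on the amide-type nitrogen gives an at least 1.3-fold higher number from compound 3 to compound 4 (0.12 log units; that floor lies within the scatter), and the same group in place of 1-methyl-2-oxopiperidin-4-yl gives an at least 1.3-fold higher number from compound 2 to compound 4 (0.14 log units; that floor lies within the scatter). Both steps are only floors, so the position is shown to accept a four-membered ring in place of a six-membered one with no loss in half-life, while the true size of the gain remains unread. The reading for compound 4 is a limit and not a number: the limit of > 1 h in this assay, at which 2 of the 4 values shown sit.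

Going by these compounds, the step between compound 1 and compound 4 cannot be read, and how far compound 4 lies past its limit stays open. Also open, on these data alone, is how a (1-acetylpyrrolidin-3-yl)methyl group, or a methanesulfonyl group in place of the acetyl, would read at this nitrogen.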